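From 2-methylphenyl to 4-fluorophenyl: a cytotoxicity estimate

The source may hold more compounds than are shown below. What is called first, only, known or untested is meant among the compounds shown, and "the series" means these compounds.

Of the compounds shown here, three with a shared core have been measured in a functional assay on DU-145 cells (Homo sapiens) for cytotoxicity, read by sulforhodamine B assay, with a stated time of 48 h; a higher number here means a weaker inhibitor, a lower number a stronger inhibitor. Compound 1 (`C[C@H]1CC[C@@H]2[C@@H](OC(=O)[C@]23CC(c2ccc([N+](=O)[O-])cc2)=NO3)[C@]2(C)C(=O)C=C[C@@]12O`) gives 7000 nM, compound 3 (`Cc1ccccc1C1=NO[C@]2(C1)C(=O)O[C@@H]1[C@H]2CC[C@H](C)[C@]2(O)C=CC(=O)[C@@]12C`) gives 12000 nM, and compound 2 (`COc1cc(C2=NO[C@]3(C2)C(=O)O[C@@H]2[C@H]3CC[C@H](C)[C@]3(O)C=CC(=O)[C@@]23C)ccc1O`) gives 71000 nM. Compound 3 thus cannot be told apart from compound 1, and compound 2 is the weakest of the three.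

Compound 4 (`C[C@H]1CC[C@@H]2[C@@H](OC(=O)[C@]23CC(c2ccc(F)cc2)=NO3)[C@]2(C)C(=O)C=C[C@@]12O`) is still unmeasured. It has 4-fluorophenyl in place of 2-methylphenyl on a carbon with a double bond to nitrogen.

Earlier changes at this same place give some guidance. Two large steps both involve the 4-hydroxy-3-methoxyphenyl group: a 10-fold higher number from compound 1 to compound 2 (1.01 log units; beyond the scatter) and a 5.9-fold lower number from compound 2 to compound 3 (0.77 log units; beyond the scatter). The new group carries neither hydroxy nor methoxy, so the better guide is the step without that group, a 1.7-fold higher number from compound 1 to compound 3 (0.23 log units; within the scatter). In this assay, the expected result is therefore no shift beyond the scatter, an estimated 1.2-fold lower number from compound 3 to compound 4 (0.08 log units; within the scatter). For compound 4 the expected value is 10000 nM, with an estimated range from 4000 nM to 30000 nM.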

Compound 4, half-maximal inhibitory concentration: 13000 nM
The estimate for compound 4 lay 1.3-fold (0.11 log units) below the measured number; low and high end bracket the measured number.
By their numbers in this assay, from the lowest: compounds 1, 3 and 4 (each within the scatter of the next); then compound 2.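

In this assay, 4-fluorophenyl joins 2-methylphenyl and 4-nitrophenyl as a third group at this carbon that cannot be told apart from the others: a 1.1-fold higher number from compound 3 to compound 4 (0.03 log units; within the scatter) and a 1.9-fold higher number from compound 1 to compound 4 (0.27 log units; within the scatter) both lie within the scatter. The third partner also sets the 4-hydroxy-3-methoxyphenyl group apart, with a 5.5-fold lower number from compound 2 to compound 4 (0.74 log units; beyond the scatter), so compound 2 is now beyond the scatter of all three others and is the weakest of the four. Nothing available gives a measured reason for this split.

The compounds shown leave open whether the hydroxy, the methoxy or the two together go with the higher number in compound 2. They also leave open whether an amine or a carboxylic acid on the phenyl ring would side with compound 2 or with the other three.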